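The source may report more compounds than this note shows. Statements on the series, on what has been measured and on what is new or still open speak of the compounds shown alone.

Compounds measured so far in an ADME assay on Vero cells (Chlorocebus sabaeus) for cytotoxicity, read by neutral red uptake, tested at 49 ug/mL; on this read-out higher numbers stand for a weaker effect at the one concentration tested and lower numbers for a stronger effect:
compound 1, `O=C1CSC(c2cccc(O)c2)N1CCN1CCCCC1`, 100%
compound 2, `O=C1CSC(c2ccc(F)cc2)N1CCN1CCCCC1`, 100%

Compound 2 stands level with compound 1 at the digits shown: the step of no change at the digits printed from compound 1 to compound 2 (within the scatter), an exchange of one substituted phenyl for another on a saturated ring carbon, lies within the scatter.

Compound 3, `O=C1CSC(c2cccc(F)c2)N1CCN1CCCCC1`, differs from compound 2 in one place: 3-fluorophenyl in place of 4-fluorophenyl on a saturated ring carbon. Among the measured compounds shown here, the one measured step that bears on this change, from compound 1 to compound 2, was itself flat, so no step beyond the scatter is expected for no change at the digits printed from compound 2 to compound 3 (within the scatter). Compound 3 is therefore expected to give about 100%, in a range from 88% to 100%.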

Compound 3, a percentage reported as activity, at one concentration (the size of the read-out at that concentration, not a potency): 97%
The estimate for compound 3 lay 3 percentage points above the measured number, and the stated range covers the measured number.
By their numbers in this assay, from the lowest: compounds 3, 1 and 2 (each within the scatter of the next).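

In this assay, 3-fluorophenyl in place of 4-fluorophenyl on the saturated ring carbon gives a number 3 percentage points lower from compound 2 to compound 3 (within the scatter), so the two fluorophenyl isomers read alike at this position. Fluoro in place of hydroxy on an aromatic carbon gives a number 3 percentage points lower from compound 1 to compound 3 (within the scatter), which isolates that exchange with the rest of the structure held the same. Nothing available offers an explanation for these results.

The compounds shown leave open how an amine or a carboxylic acid on the phenyl ring would read in this assay. They also leave open whether a longer chain on this ring carbon would read differently.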